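Dimethylphenyl variant of compound 2 in the sulfonamide series

The source may report more compounds than this note shows. Statements on the series, on what has been measured and on what is new or still open speak of the compounds shown alone.

Three members of the series have been measured in a functional assay on M21 cells (Homo sapiens) for antiproliferative activity, read by sulforhodamine B assay, with a stated time of 48 h; a higher number here means a weaker inhibitor, a lower number a stronger inhibitor. Compound 1 `O=C1NCCN1c1ccc(S(=O)(=O)Nc2ccc3[nH]ccc3c2)cc1` gives 87 nM. Compound 2 `Cc1ccc(NS(=O)(=O)c2ccc(N3CCNC3=O)cc2)cc1` gives 260 nM, the second highest of the three numbers; its nearest neighbour is compound 3 `CCCCc1ccc(NS(=O)(=O)c2ccc(N3CCNC3=O)cc2)cc1` with 450 nM, and compound 1 lies furthest from it, beyond the scatter. Compound 4 `Cc1cc(C)cc(NS(=O)(=O)c2ccc(N3CCNC3=O)cc2)c1` awaits measurement in this assay and differs from compound 2 by 3,5-dimethylphenyl in place of 4-methylphenyl on a sulfonamide nitrogen.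

For the measured compounds named here, the only measured step that alters the group on the sulfonamide nitrogen is a 1.7-fold higher number from compound 2 to compound 3 (0.24 log units; within the scatter), which lengthens the chain on the aryl ring rather than adding a second methyl, so it bears on the present change only loosely. It shows that a change of this kind on that aryl ring left the number within the scatter. Going by the values given here, no measured pair shows what a second methyl does here. The step expected is therefore a 1.3-fold higher number from compound 2 to compound 4 (0.13 log units; within the scatter), with no direction beyond the scatter. Compound 4 is estimated to give 350 nM, with a range from 150 nM to 900 nM.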

Compound 4, half-maximal inhibitory concentration: 63 nM
The estimate for compound 4 lay 5.6-fold (0.74 log units) above the measured number; the whole stated range lies above it.
By their numbers in this assay, from the lowest: compounds 4 and 1 (each within the scatter of the next); then compounds 2 and 3 (each within the scatter of the next).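

In this assay, the aryl group on the sulfonamide nitrogen now gives a step beyond the scatter: 3,5-dimethylphenyl in place of 4-methylphenyl gives a 4.1-fold lower number from compound 2 to compound 4 (0.62 log units; beyond the scatter). The earlier change on this aryl group, a 1.7-fold higher number from compound 2 to compound 3 (0.24 log units; within the scatter), stayed within the scatter, so it did not show that the number responds to the group at this position. Compound 4 at 63 nM and compound 1 at 87 nM lie within the scatter of each other, so a substituted phenyl group here can match the number of the compound 1 group.

No measurement available bears on the reason for this step. From the compounds shown here alone, it remains open whether two ethyl groups, two methoxy groups or an amine on this phenyl ring would keep the number of compound 4.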